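Trifluoromethylphenyl for Dimethoxyphenyl on the Amide Nitrogen

The source may report more compounds than this note shows. Statements on the series, on what has been measured and on what is new or still open speak of the compounds shown alone.

Compound 1 `CC(=O)Nc1ccc(Cc2noc(CCC(=O)Nc3ccccc3F)n2)cc1` gives 67.1% in a functional assay on the whole organism (strain C57BL/6) for inhibition, with Mus musculus as the target, read by paw edema, with stated times of 1 h and 4 h, at a dose of 100 mg/kg by the oral route; on this read-out lower numbers stand for less inhibition and higher numbers for more inhibition at the one dose given (going by the name of the read-out).
Compound 2 `CC(=O)Nc1ccc(Cc2noc(CCC(=O)Nc3ccc(F)cc3F)n2)cc1` gives 52.1% in this assay.
Compound 3 `COc1ccc(NC(=O)CCc2nc(Cc3ccc(NC(C)=O)cc3)no2)cc1OC` gives 95.9% in this assay.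

Compound 3 stands highest of the three, with both steps into it beyond the scatter: a number 28.8 percentage points higher from compound 1 to compound 3 (beyond the scatter) and a number 43.8 percentage points higher from compound 2 to compound 3 (beyond the scatter). Compound 4 `CC(=O)Nc1ccc(Cc2noc(CCC(=O)Nc3ccc(C(F)(F)F)cc3)n2)cc1` is not yet measured; it differs from compound 3 by 4-(trifluoromethyl)phenyl in place of 3,4-dimethoxyphenyl on an amide-type nitrogen. The two steps that bear on this are those just named, since in both a fluorinated phenyl on the amide nitrogen gives fewer points than the 3,4-dimethoxyphenyl, and the incoming group, like those of compounds 1 and 2, brings no hydrogen-bond acceptors. Compound 4 is therefore expected to fall by a number 35.9 percentage points lower from compound 3 to compound 4 (beyond the scatter) in this assay. Compound 4 is estimated at 60%, between 40% and 80%.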

Compound 4, a percentage reported as inhibition, in the whole organism at one dose (the size of the read-out at that dose, not a potency): 37%
Beside the measured number, compound 4's estimate is 23 percentage points above it; the whole stated range lies above it.
By their numbers in this assay, from the lowest: compound 4; then compound 2; then compound 1; then compound 3.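

In this assay the change to 4-(trifluoromethyl)phenyl on the amide-type nitrogen gives a number 58.9 percentage points lower from compound 3 to compound 4 (beyond the scatter) and leaves compound 4 lowest of the four, as the same group also gives a number 15.1 percentage points lower from compound 2 to compound 4 (beyond the scatter) and a number 30.1 percentage points lower from compound 1 to compound 4 (beyond the scatter) against the two fluorinated phenyls. The groups without hydrogen-bond acceptors thus differ among themselves at this position, so the lack of acceptors alone does not set the number. Nothing measured here accounts for these differences. On these data alone, what stays open is whether both methoxy groups are needed for the high reading of compound 3. As far as these compounds go, how a phenyl carrying an amine or a carboxylic acid would read at this position also stays open.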